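The compounds below may be only part of what the source reports. "The series", "measured", "known", "first", "only" and "open" are said of these compounds alone.

Measured in an assay on HEK293 cells for agonist activity at transient receptor potential cation channel subfamily M member 8 (Homo sapiens), read by fluorescence and calcium flux, with a stated time of 15 min; a higher number here means that more compound is needed for the effect, a lower number that less compound is needed:

compound 1, `CCC(C)N(Cc1cccs1)C(=O)COc1ccc(C)cc1`: 2000 nM
compound 2, `Cc1ccc(OCC(=O)N(Cc2cccs2)c2nccs2)cc1`: 2240 nM
compound 3, `Cc1ccc(OCC(=O)N(Cc2cccs2)C2COC2)cc1`: 23000 nM

Compound 3 gives the highest number of the three. Its nearest neighbour is compound 2, reached by a 10-fold higher number from compound 2 to compound 3 (1.01 log units; beyond the scatter), and the furthest is compound 1, reached by a 12-fold higher number from compound 1 to compound 3 (1.06 log units; beyond the scatter); both steps lie beyond the scatter. Compound 1 and compound 2 sit together, the step of a 1.1-fold higher number from compound 1 to compound 2 (0.05 log units; within the scatter) being within the scatter, so the two substituents without a four-membered ring on the amide-type nitrogen behave alike, and the oxetan-3-yl of compound 3 stands apart.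

The next compound, compound 4, is `Cc1ccc(OCC(=O)N(Cc2cccs2)C(C)(C)C)cc1`. It differs from compound 3 as follows: tert-butyl in place of oxetan-3-yl on an amide-type nitrogen. The change removes the one four-membered non-aromatic ring and its single hydrogen-bond acceptor and puts in a saturated group of the same atom count, closer in kind to the sec-butyl of compound 1 than to the oxetan-3-yl of compound 3.

Going by the values given here, the steps that bear on this are those from compound 1 and compound 2 to compound 3, both large and both in the direction of a higher number. Reversing the kind of change made there, a large step in the opposite direction is expected in this assay, bringing compound 4 back toward the numbers of compound 1 and compound 2. The expected step is a 9.2-fold lower number from compound 3 to compound 4 (0.96 log units; beyond the scatter). Compound 4 is therefore estimated at 2500 nM, with a range from 900 nM to 8000 nM.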

Compound 4, half-maximal effective concentration: 11000 nM
The estimate for compound 4 lay 4.4-fold (0.64 log units) below the measured number; the whole stated range lies below it.
By their numbers in this assay, from the lowest: compounds 1 and 2 (each within the scatter of the next); then compound 4; then compound 3.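

In this assay, tert-butyl in place of oxetan-3-yl on the amide-type nitrogen gives a 2.1-fold lower number from compound 3 to compound 4 (0.32 log units; beyond the scatter) and so undoes only part of the rise seen with oxetan-3-yl, since compound 4 still shows a 4.9-fold higher number from compound 2 to compound 4 (0.69 log units; beyond the scatter) and a 5.5-fold higher number from compound 1 to compound 4 (0.74 log units; beyond the scatter). The earlier compounds shown here allowed a simple split at this position, with oxetan-3-yl on one side and the groups without a four-membered ring on the other, but compound 4 goes against that split: it has no such ring and no hydrogen-bond acceptor in this group, yet it does not join compound 1 or compound 2. The position therefore also separates two saturated carbon groups, tert-butyl and sec-butyl, and no measurement at hand accounts for that separation.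

The compounds shown leave open whether the high number of compound 3 goes with the four-membered ring or with its oxygen, a question that cyclobutyl at the same place would address. Also open, going by these compounds, is how a straight n-butyl chain or a chain ending in an amine would sit relative to sec-butyl and tert-butyl.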